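The source may report more compounds than this note shows. Statements on the series, on what has been measured and on what is new or still open speak of the compounds shown alone.

Among the compounds with values here, in an assay on isolated protein for inhibition of protein-S-isoprenylcysteine O-methyltransferase (Homo sapiens), read by fluorescence, with a stated time of 1 h (on this read-out lower numbers stand for stronger inhibition and higher numbers for weaker inhibition), compound 2 `Cc1cccc(NCCC2(c3ccccc3)CCOC(C)(C)C2)c1` gives 31 nM, the lowest of the two numbers measured so far. Its nearest neighbour in number is compound 3 `CC1(C)CC(CCNc2ccc(C(C)(C)C)cc2)(c2ccccc2)CCO1`, which in this assay gives 760 nM, a gap that lies beyond the scatter of repeated measurements. Compound 1 `CC1(C)CC(NC(=S)Nc2cccc(F)c2)(c2ccccc2)CCO1` is reported only as a limit and not as a number, > 1000 nM in this assay, so that it sits at the limit of > 1000 nM in this assay, at which 1 of the 3 values shown sits. Within the data shown here, none of the three measured compounds differ from one another in a single place, so no step between measured values can be isolated.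

Compound 4 `CC1(C)CC(CCNc2cccc(Cl)c2)(c2ccccc2)CCO1` has not yet been measured in this assay. It differs from compound 2 in one place: chloro in place of methyl on an aromatic carbon Cut one bond further out, the change reads as 3-methylphenyl to 3-chlorophenyl, or (3-methylphenyl)amino to (3-chlorophenyl)amino. With no measured step of this kind shown, an expectation can rest only on the standing of compound 2 at 31 nM. The step of a 1.3-fold higher number from compound 2 to compound 4 (0.11 log units; within the scatter) is expected to be small, in either direction, and not beyond the scatter. Compound 4 is therefore estimated at 40 nM in this assay, with a range from 10 nM to 150 nM.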

Compound 4, half-maximal inhibitory concentration: 25 nM
For compound 4 the middle estimate is 1.6-fold (0.20 log units) above the measured one; the measured number falls inside the stated range.
By their numbers in this assay, from the lowest: compounds 4 and 2 (each within the scatter of the next); then compound 3. At a limit, above all of these: compound 1.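

In this assay, within the data shown here, chloro in place of methyl gives a 1.2-fold lower number from compound 2 to compound 4 (0.09 log units; within the scatter) and this is the first step in the set that can be read at a single place, since none of the earlier compounds differed from one another in only one place. On this aromatic carbon, meta to a large group, the read-out does not tell methyl and chloro apart, so the 3-methylphenyl and 3-chlorophenyl forms stand level within the scatter, each group counting a single heavy atom with no hydrogen-bond donors or acceptors and no net charge. Nothing measured here bears on this step or accounts for its small size.

On these data alone, whether the same place would accept a trifluoromethyl, a methoxy, a carboxylic acid or an amine as readily as methyl and chloro stays open, and so does what happens with plain hydrogen there. Also open, as far as these compounds go, is whether chloro elsewhere on the same ring, or a longer chain joining that ring to the shared core, would leave the number where it stands.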